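From allyloxy to chloromethyl on a carbonyl carbon

The compounds below may be only part of what the source reports. "The series", "measured", "known", "first", "only" and "open" are said of these compounds alone.

Compound 1 `CC(C)COC(=O)N1CCCc2cc(S(=O)(=O)N3CC(c4ccccc4)NC3=O)ccc21` measures 2380 nM
Compound 2 `CCCCOC(=O)N1CCCc2cc(S(=O)(=O)N3CC(c4ccccc4)NC3=O)ccc21` measures 3680 nM
Compound 3 `C=CCOC(=O)N1CCCc2cc(S(=O)(=O)N3CC(c4ccccc4)NC3=O)ccc21` measures 473 nM

In a functional assay on K562 cells (Homo sapiens) for antiproliferative activity, read by MTT assay (a higher number here means a weaker inhibitor, a lower number a stronger inhibitor), compound 3 has the lowest number of the three, beyond the scatter of compound 1 (a 5.0-fold lower number from compound 1 to compound 3 (0.70 log units; beyond the scatter)) and of compound 2 (a 7.8-fold lower number from compound 2 to compound 3 (0.89 log units; beyond the scatter)). Compound 4 `O=C(CCl)N1CCCc2cc(S(=O)(=O)N3CC(c4ccccc4)NC3=O)ccc21` carries chloromethyl in place of allyloxy on a carbonyl carbon. The measured steps bear on this only indirectly, since each swaps one chain for another and none introduces chloromethyl. They range from a change within the scatter (a 1.5-fold higher number from compound 1 to compound 2 (0.19 log units; within the scatter)) to the two modest steps above. They indicate no direction, so no step beyond the scatter is expected, with wide uncertainty. Compound 4 is estimated at 700 nM (range 130 nM to 3500 nM). This estimate means an expected step (a 1.5-fold higher number from compound 3 to compound 4 (0.17 log units; within the scatter)).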

Compound 4, half-maximal inhibitory concentration: 1100 nM
Beside the measured number, compound 4's estimate is 1.6-fold (0.20 log units) below it; measured number inside the range.
By their numbers in this assay, from the lowest: compound 3; then compound 4; then compounds 1 and 2 (each within the scatter of the next).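

In this assay the carbonyl carbon bound to the amide-type nitrogen in a ring still gives an active compound when its oxygen-linked chain gives way to chloromethyl. Allyloxy keeps the lower number (a 2.3-fold higher number from compound 3 to compound 4 (0.37 log units; beyond the scatter)), yet chloromethyl gives a lower number than butoxy (a 3.3-fold lower number from compound 2 to compound 4 (0.52 log units; beyond the scatter)) and isobutoxy (a 2.2-fold lower number from compound 1 to compound 4 (0.34 log units; beyond the scatter)), so compound 4 falls within the span of the oxygen-linked chains. No measurement here accounts for this order.

The compounds shown leave open whether the chlorine matters, as a plain methyl or a bromomethyl at this place would show. From the compounds shown here alone, how an aminomethyl group or a propargyloxy chain would compare also remains open.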